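Substituent swap on the aryl ring: compound 3 to compound 4

The compounds below may be only part of what the source reports. "The series", "measured", "known", "first", "only" and "open" are said of these compounds alone.

Measured in an assay for inhibition of ribonucleoside-diphosphate reductase RR1 (Homo sapiens), with a stated time of 30 min; a higher number here means a weaker inhibitor, a lower number a stronger inhibitor:
compound 1 `Oc1ccc(/C=N/NC(=S)Nc2ccccc2)cc1`: 242000 nM
compound 2 `Cc1ccccc1NC(=S)N/N=C/c1ccc(O)cc1`: 36500 nM
compound 3 `O=[N+]([O-])c1ccccc1NC(=S)N/N=C/c1ccc(O)cc1`: 39300 nM

Compound 3 and compound 2 lie within the scatter of each other, as a 1.1-fold higher number from compound 2 to compound 3 (0.03 log units; within the scatter) shows, while compound 1 stands well apart: a 6.2-fold lower number from compound 1 to compound 3 (0.79 log units; beyond the scatter). Compound 4 `Oc1ccc(/C=N/NC(=S)Nc2ccccc2O)cc1` differs from compound 3 by hydroxy in place of nitro on an aromatic carbon. The steps bearing on this are the two entries on that aromatic carbon, a 6.6-fold lower number from compound 1 to compound 2 (0.82 log units; beyond the scatter) and a 6.2-fold lower number from compound 1 to compound 3 (0.79 log units; beyond the scatter), both modest and of like size, and the swap a 1.1-fold higher number from compound 2 to compound 3 (0.03 log units; within the scatter), within the scatter. Within the data shown here, two unlike groups there gave the same result, so the hydroxy is expected to behave alike, with a 1.5-fold higher number from compound 3 to compound 4 (0.18 log units; within the scatter) expected to remain within or near the scatter; no hydroxy analogue is measured, so the range is wide. Compound 4 is estimated at 60000 nM, range 20000 nM to 250000 nM, in this assay.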

Compound 4, half-maximal inhibitory concentration: 29300 nM
Beside the measured number, compound 4's estimate is 2.0-fold (0.31 log units) above it, and the stated range covers the measured number.
By their numbers in this assay, from the lowest: compounds 4, 2 and 3 (each within the scatter of the next); then compound 1.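

In (this assay), hydroxy on this aromatic carbon cannot be told apart from nitro (a 1.3-fold lower number from compound 3 to compound 4 (0.13 log units; within the scatter)) or from methyl (a 1.2-fold lower number from compound 2 to compound 4 (0.10 log units; within the scatter)). Against hydrogen at the same carbon, hydroxy gives a step of similar size to those of the other two groups (an 8.3-fold lower number from compound 1 to compound 4 (0.92 log units; beyond the scatter)), so all three substituted compounds stand apart from compound 1 despite their different hydrogen-bond donor counts. No measurement available here accounts for this sameness.

Open: whether an amine, a carboxylic acid or a longer chain on this carbon would keep the same result.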